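The compounds below may be only part of what the source reports. "The series", "measured", "known", "first", "only" and "open" are said of these compounds alone.

Measured compounds in an assay on CHO cells for displacement of a labelled ligand from adenosine receptor A1 (Homo sapiens); on this read-out lower numbers stand for tighter binding and higher numbers for weaker binding:
compound 1, `Nc1scc(CN2CCN(c3ccccc3)CC2)c1C(=O)c1ccc(Cl)cc1`, gives 1.9 nM.
compound 2, `Nc1scc(CN2CCN(c3ccc(F)cc3)CC2)c1C(=O)c1ccc(Cl)cc1`, gives 1.8 nM.
compound 3, `Nc1scc(CN2CCN(c3ccc(Cl)cc3)CC2)c1C(=O)c1ccc(Cl)cc1`, gives 1.8 nM.

Compound 3 stands level with compound 2 at the digits recorded, the two together being the lowest numbers of the three, and its nearest neighbour is compound 2, with no change at the digits recorded. Its furthest neighbour is compound 1, and the step of a 1.1-fold lower number from compound 1 to compound 3 (0.02 log units; within the scatter) lies within the scatter, as does the step of a 1.1-fold lower number from compound 1 to compound 2 (0.02 log units; within the scatter) and the step of no change at the digits printed from compound 2 to compound 3 (within the scatter). So far, then, the aromatic carbon in question has carried hydrogen, fluoro and chloro with no movement beyond the scatter in this assay.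

Compound 4, `N#Cc1ccc(N2CCN(Cc3csc(N)c3C(=O)c3ccc(Cl)cc3)CC2)cc1`, differs from compound 3 by cyano in place of chloro on an aromatic carbon. Within the data shown here, no measured step introduces cyano here; the three steps that do bear on the position, all within the scatter, show that exchanging the group on this carbon among hydrogen, fluoro and chloro did not move the number. On that basis, compound 4 is expected to sit close to compound 3, with a step of a 1.4-fold higher number from compound 3 to compound 4 (0.14 log units; within the scatter) that stays within the scatter, although a cyano group is a new case and a small shift in either direction cannot be excluded.

Compound 4 is estimated at 2.5 nM, within 1 nM to 7 nM.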

Compound 4, dissociation constant: 1.8 nM
The estimate for compound 4 lay 1.4-fold (0.14 log units) above the measured number; the range from low to high includes it.
By their numbers in this assay, from the lowest: compounds 2, 3, 4 and 1 (each within the scatter of the next).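

In this assay, the change from 4-chlorophenyl to 4-cyanophenyl gives (no change at the digits printed from compound 3 to compound 4 (within the scatter)), and the two other comparisons read the same way: cyano against fluoro gives (no change at the digits printed from compound 2 to compound 4 (within the scatter)) and cyano against hydrogen gives (a 1.1-fold lower number from compound 1 to compound 4 (0.02 log units; within the scatter)). The aromatic carbon para to a large group therefore accepts, within the scatter, a group of two heavy atoms with a triple bond and a hydrogen-bond acceptor, which extends the flat picture beyond the single-atom cases of hydrogen, fluoro and chloro across all four compounds. No evidence is at hand that would explain why the number holds across these groups.

On these data alone, whether this flat response survives at the same carbon with groups of another kind, such as an amine, a carboxylic acid or a longer chain, remains open. All four compounds also share the rest of the structure, including the chloro on the other aromatic ring, so they cannot show whether the position stays this undemanding once the shared core is altered.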